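Cytotoxicity notes on a tetrazole series in HaCaT cells

The compounds below may be only part of what the source reports. "The series", "measured", "known", "first", "only" and "open" are said of these compounds alone.

Measured so far:
compound 1, `COc1ccc(Nc2nnnn2-c2ccc(Br)cc2)cc1`, 103000 nM
compound 2, `COc1ccc(-n2nnnc2Nc2ccc(Br)cc2)cc1`, 131000 nM

Of the compounds shown here, two have been read in an ADME assay on HaCaT cells (Homo sapiens) for cytotoxicity, read by MTT assay, with a stated time of 72 h; on this read-out higher numbers stand for weaker inhibition and lower numbers for stronger inhibition. Compound 1 gives 103000 nM in this assay. The other one, compound 2, gives 131000 nM in this assay and carries the higher of the two numbers, but its gap to compound 1 lies within the usual scatter of repeated measurements, so the two values are taken as indistinguishable. Both stand at weak cytotoxicity.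

Among the measured compounds shown here, the next compound, compound 3, `COc1ccc(-n2nnnc2Nc2cccc(Cl)c2)cc1`, has not yet been read. Against compound 2 it differs in one place: 3-chlorophenyl in place of 4-bromophenyl on a nitrogen on an aromatic ring. For the measured compounds named here, no measured pair shows the effect of such a change, so nothing in the data fixes its direction or size.

Going by the values given here, with both known values at weak cytotoxicity and no comparable step available, compound 3 is expected to stay close to compound 2, giving an estimated step of a 1.1-fold lower number from compound 2 to compound 3 (0.04 log units; within the scatter) in this assay, not beyond the scatter. The estimate for compound 3 in this assay is 120000 nM, with a range from 50000 nM to 280000 nM.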

Compound 3, half-maximal inhibitory concentration: 141000 nM
For compound 3 the middle estimate is 1.2-fold (0.07 log units) below the measured one; low and high end bracket the measured number.
By their numbers in this assay, from the lowest: compounds 1, 2 and 3 (each within the scatter of the next).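

In this assay the exchange of 4-bromophenyl for 3-chlorophenyl on a nitrogen on an aromatic ring gives a 1.1-fold higher number from compound 2 to compound 3 (0.03 log units; within the scatter) and so leaves the read-out at this position without a change beyond the scatter. Among the compounds shown here, both the halogen and its place on the phenyl ring differ in this pair, so the step shows only that the two changes taken together leave the cytotoxicity weak, with compound 3 at 141000 nM in the same range as compound 2 at 131000 nM and no separate contribution from either change can be read. Nothing available on the compounds bears on why these two values lie so close.

Still open, going by these compounds, is how 3-bromophenyl or 4-chlorophenyl would read at this position, and these two groups would separate the halogen from its place on the ring. Also open, on these data alone, is whether a phenyl carrying an amine or a carboxylic acid, or a longer alkyl chain in place of the phenyl ring, would stay in the same weak range in this assay or move beyond the scatter.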